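Pyridinyl Swap at the Exocyclic Carbon: Compound 4

This account rests on a few compounds, and the source may have more. Where it says the series, first, only, none or still open, it means among the compounds named here.

Compound 1 `CCOC(=O)C1=C(Nc2ccccc2)S/C(=C\c2ccc(OC)cc2)C1=O` is assessed in a functional assay on MCF7 cells (Homo sapiens) for inhibition, read by MTT assay, with a stated time of 72 h, tested at 10 uM (on this read-out higher numbers stand for more inhibition at the one concentration tested (going by the name of the read-out) and lower numbers for less inhibition), where compound 1 gives 14.7%. Compound 3 `CCOC(=O)C1=C(Nc2cccc([N+](=O)[O-])c2)S/C(=C\c2ccc[nH]2)C1=O` gives 27.4% in this assay. Compound 2 `CCOC(=O)C1=C(Nc2ccc(F)cc2)S/C(=C\c2ccc[nH]2)C1=O` reaches only < 10% in this assay, a limit rather than a number. Of the two numbers, compound 1 stands lowest, with compound 3 above it by a gap beyond the scatter. Going by the values given here, the one measured step, a number at least 17.4 percentage points higher from compound 2 to compound 3 (beyond the scatter), changes the group on the amine nitrogen. Note also (the limit of < 10% in this assay, at which 1 of the 3 values shown sits). Compound 4 `CCOC(=O)C1=C(Nc2ccccc2)S/C(=C\c2cccnc2)C1=O` is not yet measured. It differs from compound 1 by pyridin-3-yl in place of 4-methoxyphenyl on a double-bonded chain carbon bound to a double-bonded ring carbon. Among the compounds with values here, no measured step touches this position, so no change beyond the scatter is expected. Compound 4 is therefore expected near 13%, within 5% to 25%. The expected step is a number 1.7 percentage points lower from compound 1 to compound 4 (within the scatter).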

Compound 4, a percentage reported as inhibition, at one concentration (the size of the read-out at that concentration, not a potency): < 10%
Compound 4: no number, only a limit; the forecaster's own chance of this, stated with the estimate: 35%; at least 3 percentage points between middle value and limit.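

In this assay compound 4 gives only a limit, not a number. Going by these compounds alone, this is the first change read at this position, and pyridin-3-yl in place of 4-methoxyphenyl brings no gain: the step is a number at least 4.7 percentage points lower from compound 1 to compound 4 (that floor lies within the scatter), and its true size cannot be read. The series also gathers at the bottom of the scale: the limit of < 10% in this assay, at which 2 of the 4 values shown sit.

Open, as far as these compounds go, is how this position responds to groups other than aromatic rings, such as an amine or a carboxylic acid in place of pyridin-3-yl on the same carbon.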